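The source may hold more compounds than are shown below. What is called first, only, known or untested is meant among the compounds shown, and "the series" means these compounds.

Among the compounds with values here, in a functional assay on A549 cells (Homo sapiens) for inhibition, read by XTT assay, with a stated time of 48 h (a higher number here means a weaker inhibitor, a lower number a stronger inhibitor), compound 2 `COc1ccc(C(=O)/C(=C/c2ccc(Cl)cc2Cl)CCOC(C)=O)cc1` gives 69200 nM, the only number measured so far in this small set. Compound 1 `CCC(/C=C(\COC(C)=O)C(=O)c1ccc(OC)cc1)CC` reaches only a limit of the assay, > 100000 nM, and so supplies no number. That is the assay's limit, (the limit of > 100000 nM in this assay, at which 1 of the 2 values shown sits), and nothing more can be read from it. Compound 3 `COc1ccc(C(=O)/C(=C/c2ccc([N+](=O)[O-])cc2)CCOC(C)=O)cc1` differs from compound 2 by 4-nitrophenyl in place of 2,4-dichlorophenyl on a double-bonded chain carbon bound to a double-bonded chain carbon. Within the data shown here, no measured pair shows what such a change does here, so the step of a 1.3-fold lower number from compound 2 to compound 3 (0.10 log units; within the scatter) is expected to stay within the usual scatter. Compound 3 is therefore estimated at 55000 nM, with a range from 15000 nM to 150000 nM.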

Compound 3, half-maximal inhibitory concentration: > 100000 nM
Compound 3: a limit, no number; the forecaster's own chance of this, stated with the estimate: 35%; at least 1.8-fold (0.25 log units) between middle value and limit.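

In this assay compound 3 gives > 100000 nM, which is a limit of the assay and not a number. Within the data shown here, putting 4-nitrophenyl in place of 2,4-dichlorophenyl on a double-bonded chain carbon bound to a double-bonded chain carbon gives the first measured step at this position, an at least 1.4-fold higher number from compound 2 to compound 3 (0.15 log units; that floor lies within the scatter), so only a floor is known, and it does not by itself establish a real loss. Most of the set now sits at one limit: the limit of > 100000 nM in this assay, at which 2 of the 3 values shown sit.

On these data alone, the true size of this step stays open. Also open, as far as these compounds go, is how a plain phenyl or a 4-aminophenyl would read in this place.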